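The source may report more compounds than this note shows. Statements on the series, on what has been measured and on what is new or still open speak of the compounds shown alone.

Series notes. In an assay on NIH3T3 cells with Urotensin-2 receptor (Homo sapiens) as the target (on this read-out lower numbers stand for an effect already at smaller amounts and higher numbers for an effect only at larger amounts of compound), compound 1 `Cc1c(Cl)cccc1C(=O)NC(CCN(C)C)c1ccc(Cl)cc1` gives 1740 nM. Among the measured compounds shown here, compound 2 `Cc1ccc(C)c(C(=O)NC(CCN(C)C)c2ccc(Cl)cc2)c1` gives 2880 nM in this assay, the highest of the two numbers so far; its only neighbour is compound 1, and the step of a 1.7-fold higher number from compound 1 to compound 2 (0.22 log units; within the scatter) stays within the scatter. Compound 3 `Cc1cc(C)c(C(=O)NC(CCN(C)C)c2ccc(Cl)cc2)cc1C` is not yet measured. It differs from compound 2 by methyl in place of hydrogen on an aromatic carbon. For the measured compounds named here, the single measured step of a 1.7-fold higher number from compound 1 to compound 2 (0.22 log units; within the scatter) exchanged one set of small substituents on the aromatic ring for another and moved the number by no more than the scatter, so the only precedent available suggests that one more methyl on the same ring leaves the number roughly where it is. For compound 3 the expected step in this assay is a 1.0-fold higher number from compound 2 to compound 3 (0.02 log units; within the scatter), in no particular direction beyond the scatter. For compound 3 the estimated value in this assay is 3000 nM, with a range from 1200 nM to 7500 nM.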

Compound 3, half-maximal effective concentration: 1780 nM
Compound 3: the middle estimate sits 1.7-fold (0.23 log units) above what was measured, within the range that was stated.
By their numbers in this assay, from the lowest: compounds 1, 3 and 2 (each within the scatter of the next).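

In this assay, methyl in place of hydrogen on an aromatic carbon, ortho to a methyl group, meta to a methyl group and para to a large group, gives a 1.6-fold lower number from compound 2 to compound 3 (0.21 log units; within the scatter). Whereas the step of a 1.7-fold higher number from compound 1 to compound 2 (0.22 log units; within the scatter) exchanged one substituent set for another, this one adds a single carbon to the ring, and at this position the read-out does not separate hydrogen from methyl. No accompanying measurement bears on this result.

The compounds shown leave open whether methoxy, ethyl or a carboxylic acid in place of this methyl would give a step beyond the scatter. Going by these compounds, all three share the rest of the core, so the effect of a longer chain in place of the one carrying the dimethylamine also remains open.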